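A few compounds are considered here, and "the series" means these few. Any claim that something is new, unique, unknown or untested is made for them only; others in the source may bear on it.

In an assay on CHO cells for displacement of a labelled ligand from 5-hydroxytryptamine receptor 1B (Homo sapiens) (a lower number here means a stronger inhibitor, a higher number a weaker inhibitor), compound 2 `c1ccc(CNCC2CCN(CCCc3c[nH]c4ccc(-n5cnnc5)cc34)CC2)cc1` gives 28 nM, the lowest of the two numbers in hand; the nearest is compound 1 `O=S(=O)(NCC1CCN(CCCc2c[nH]c3ccc(-n4cnnc4)cc23)CC1)c1ccccc1` with 60 nM, and the step of a 2.1-fold lower number from compound 1 to compound 2 (0.33 log units; beyond the scatter) came with benzyl in place of phenylsulfonyl on the amine nitrogen. Among the measured compounds shown here, compound 3 `c1ccc2c(c1)CCC2NC1CCN(CCCc2c[nH]c3ccc(-n4cnnc4)cc23)CC1` carries (2,3-dihydro-1H-inden-1-yl)amino in place of (benzylamino)methyl on a saturated ring carbon, a change at the same end of the shared core but of another kind, so that earlier step bears on it only loosely and no measured step covers it directly. From this, a step of a 1.1-fold higher number from compound 2 to compound 3 (0.03 log units; within the scatter) is expected, one that should stay within the scatter. Compound 3 is estimated at 30 nM, range 8 nM to 110 nM.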

Compound 3, half-maximal inhibitory concentration: 280 nM
The estimate for compound 3 lay 9.3-fold (0.97 log units) below the measured number; measured number above the stated range.
By their numbers in this assay, from the lowest: compound 2; then compound 1; then compound 3.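

In this assay this saturated ring carbon proves far more sensitive than the earlier pair suggested: a 10-fold higher number from compound 2 to compound 3 (1.00 log units; beyond the scatter) came with (2,3-dihydro-1H-inden-1-yl)amino in place of (benzylamino)methyl, against a 2.1-fold lower number from compound 1 to compound 2 (0.33 log units; beyond the scatter) for the earlier change. The entering group also falls behind the ((phenylsulfonyl)amino)methyl group, with a 4.7-fold higher number from compound 1 to compound 3 (0.67 log units; beyond the scatter) on that swap. Nothing available explains the loss.

On these data alone, compound 3 changes both the link to the ring and the group on the amine nitrogen, so their shares in the loss stay open. A benzylamino group directly on that ring carbon, or a (2,3-dihydro-1H-inden-1-yl)aminomethyl group, would separate them.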